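Flavonol benzyl ethers: cytotoxicity step toward compound 3

This account rests on a few compounds, and the source may have more. Where it says the series, first, only, none or still open, it means among the compounds named here.

Compound 1 `O=c1c(OCc2ccccc2Br)c(-c2ccccc2)oc2cc(O)cc(O)c12` and compound 2 `COc1ccccc1COc1c(-c2ccccc2)oc2cc(O)cc(O)c2c1=O` share one core and differ only in the benzyl ether substituent. In an ADME assay on Huh-5-2 cells (Homo sapiens) for cytotoxicity, read by WST assay, with a stated time of 3 days (on this read-out higher numbers stand for lower toxicity in this test and lower numbers for higher toxicity in this test), compound 1 gives 12000 nM, and in this assay compound 2 gives 53000 nM. The step of a 4.4-fold higher number from compound 1 to compound 2 (0.65 log units; beyond the scatter) is the only measured one, and it places compound 2 with the highest number of the two, a modest distance from compound 1. Compound 3 `Cc1ccc(COc2c(-c3ccccc3)oc3cc(O)cc(O)c3c2=O)cc1` is the next member, differing from compound 2 as follows: 4-methylphenyl in place of 2-methoxyphenyl on a saturated chain carbon bound to an oxygen on an aromatic ring. Among the compounds with values here, no measured step touches this particular exchange; the one known step concerns methoxy in place of bromo, a different change, and it was modest in size. The expected step from compound 2 to compound 3 is therefore small, a 1.8-fold lower number from compound 2 to compound 3 (0.25 log units; within the scatter), with no confident direction. Compound 3 is estimated at 30000 nM, within a range of 10000 nM to 90000 nM.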

Compound 3, half-maximal cytotoxic concentration: 40000 nM
Compound 3: the middle estimate sits 1.3-fold (0.12 log units) below what was measured, and the stated range covers the measured number.
By their numbers in this assay, from the lowest: compound 1; then compounds 3 and 2 (each within the scatter of the next).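

On a saturated chain carbon bound to an oxygen on an aromatic ring, the exchange of 2-methoxyphenyl for 4-methylphenyl gives a 1.3-fold lower number from compound 2 to compound 3 (0.12 log units; within the scatter) in this assay, so this test does not separate these two groups. The second comparison, a 3.3-fold higher number from compound 1 to compound 3 (0.52 log units; beyond the scatter), means that compound 1, with its 2-bromophenyl group, now stands beyond the scatter below both other compounds, which is a distinction that a single step could not show. Nothing available here explains this difference.

The compounds shown leave open whether the low number of compound 1 belongs to bromo itself or to its place on the ring, since 4-methylphenyl differs from 2-bromophenyl in both group and ring position. They also leave open how an amine, a carboxylic acid or a longer chain at this position would read in this assay.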